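A few compounds are considered here, and "the series" means these few. Any claim that something is new, unique, unknown or untested is made for them only; others in the source may bear on it.

In an ADME assay on Akata cells (Homo sapiens) for cytotoxicity, with a stated time of 7 days (a higher number here means that more compound is tolerated, a lower number that less compound is tolerated), three compounds on a shared core have so far returned only limits, not numbers. Compound 3 `Nc1nc(NCc2ccccc2)c2ncn(/C=C3/CC3(CO)CO)c2n1` gives > 24000 nM, which is a limit. Compound 1 `COCCOc1nc(N)nc2c1ncn2/C=C1/CC1(CO)CO` gives > 20000 nM, also a limit. Compound 2 `CCCCCCCCOc1nc(N)nc2c1ncn2/C=C1/CC1(CO)CO` gives > 20000 nM, again a limit. Compound 4 `CCCCCCCCSc1nc(N)nc2c1ncn2/C=C1/CC1(CO)CO` has octylsulfanyl in place of benzylamino on an aromatic carbon. The closest measured change is a step that the two limits leave unreadable from compound 2 to compound 3, with benzylamino in place of octyloxy. The others are a step that the two limits leave unreadable from compound 1 to compound 3 and a step that the two limits leave unreadable from compound 1 to compound 2. None of these has a readable size, so no step beyond the scatter is expected. The estimated change is an at least 1.2-fold lower number from compound 3 to compound 4 (0.07 log units; that floor lies within the scatter). For compound 4 the expected value is 20000 nM, with an estimated range from 8000 nM to 40000 nM.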

Compound 4, half-maximal cytotoxic concentration: > 20000 nM
Compound 4: a limit, no number; the forecaster's own chance of this, stated with the estimate: 70%; the middle value sits exactly at the limit.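

Compound 4 also returned only a limit, so no step to compound 1, compound 2 or compound 3 can be read: the limit of > 20000 nM in this assay, at which 3 of the 4 values shown sit.

On these data alone, what stays open is the actual half-maximal cytotoxic concentration of each of these four compounds, and whether exchanging these groups changes it at all.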